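Fluoro Substituents in a Benzothiazolyl Thiourea Cytotoxicity Series

The source may report more compounds than this note shows. Statements on the series, on what has been measured and on what is new or still open speak of the compounds shown alone.

Measured compounds:
- compound 1, `S=C(Nc1ccc(Cl)cc1)Nc1nc2ccccc2s1`: 39000 nM
- compound 2, `Fc1ccc2nc(NC(=S)Nc3ccc(Cl)cc3)sc2c1`: 31200 nM
- compound 3, `CCOc1ccc2nc(NC(=S)Nc3ccccc3)sc2c1`: 43800 nM

All three were run in a functional assay on THP-1 cells (Homo sapiens) for cytotoxicity, read by MTT assay, with a stated time of 48 h; on this read-out higher numbers stand for weaker inhibition and lower numbers for stronger inhibition. The step of a 1.3-fold lower number from compound 1 to compound 2 (0.10 log units; within the scatter) is fluoro in place of hydrogen on an aromatic carbon, and it lies within the scatter. The difference between the core of compound 1 and the core of compound 3 is not broken down here; the values of compound 1 and compound 3 stand within the scatter of one another.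

Compound 4, `CCOc1ccc2nc(NC(=S)Nc3ccc(F)cc3)sc2c1`, is not yet measured. It differs from compound 3 by fluoro in place of hydrogen on an aromatic carbon. This is the same kind of change as that from compound 1 to compound 2, but the place differs: there the fluoro entered on a ring that is part of a fused or bridged system of two rings, meta to a fused ring and para to a fused ring; here it enters para to a large group.

Because the earlier step of a 1.3-fold lower number from compound 1 to compound 2 (0.10 log units; within the scatter) stayed within the scatter, a step of similar size, a 1.3-fold lower number from compound 3 to compound 4 (0.10 log units; within the scatter), is expected. Compound 4 is therefore estimated at 35000 nM in this assay , between 18000 nM and 70000 nM.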

Compound 4, half-maximal inhibitory concentration: 39500 nM
For compound 4 the middle estimate is 1.1-fold (0.05 log units) below the measured one; measured number inside the range.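

In this assay the change from phenyl to 4-fluorophenyl gives a 1.1-fold lower number from compound 3 to compound 4 (0.04 log units; within the scatter). Fluoro in place of hydrogen on an aromatic carbon thus carries over without a measurable difference between the two cores, although it enters at a different place on each: the same change on two cores in this assay, a 1.3-fold lower number (0.10 log units; within the scatter) from compound 1 to compound 2 and a 1.1-fold lower number (0.04 log units; within the scatter) from compound 3 to compound 4, 1.1-fold (0.05 log units) apart, within the scatter of two such steps. Within the data shown here, this shows only that neither step leaves the scatter, not that the fluoro has no effect in general, nor how it would behave at the same place on both cores.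

On these data alone, whether an amine, a carboxylic acid or a trifluoromethyl group on that aromatic carbon would move the number beyond the scatter stays open. So does whether any such step would carry from one core to the other.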